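Replacing the (ethoxymethyl)carbonyl group of compound 2

A few compounds are considered here, and "the series" means these few. Any claim that something is new, unique, unknown or untested is made for them only; others in the source may bear on it.

Measured in a functional assay on MCF7 cells (Homo sapiens) for cytotoxicity, read by MTT assay, with a stated time of 24 h; on this read-out lower numbers stand for stronger inhibition and higher numbers for weaker inhibition:
Compound 1 `COc1ccc(Cn2c(-c3cc(OC)c(OC)c(OC)c3)cc3cc(OC)ccc32)cc1`: > 30000 nM (a limit)
Compound 2 `CCOCC(=O)Oc1ccc(Cn2c(-c3cc(OC)c(OC)c(OC)c3)cc3cc(OC)ccc32)cc1`: > 30000 nM (a limit)

Neither compound gives a number. Compound 2 stands at > 30000 nM, which is a limit. Compound 1 stands at > 30000 nM, which is also a limit. The data therefore offer only (the limit of > 30000 nM in this assay, at which 2 of the 2 values shown sit).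

Compound 3 `COc1ccc2c(c1)cc(-c1cc(OC)c(OC)c(OC)c1)n2Cc1ccc(OC(C)CN(C)C)cc1` keeps the core of compound 2 and carries 1-((dimethylamino)methyl)ethyl in place of (ethoxymethyl)carbonyl on an oxygen on an aromatic ring. The entering group brings a nitrogen that neither earlier compound has.

Going by the values given here, the only measured step at this oxygen is a step that the two limits leave unreadable from compound 1 to compound 2, so it provides no size to carry over. The expectation thus rests on the structural change alone, and it is a weak one. A modest move towards stronger inhibition in this assay is expected, though another limit remains quite possible. The estimated change is an at least 2.5-fold lower number from compound 2 to compound 3 (0.39 log units; beyond the scatter). For compound 3 the expected value is 12000 nM, with an estimated range of 3000 nM to 30000 nM.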

Compound 3, half-maximal inhibitory concentration: 14700 nM
For compound 3 the middle estimate is 1.2-fold (0.09 log units) below the measured one, and the stated range covers the measured number.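

In this assay compound 3 gives 14700 nM, a number and not a limit, which shows that a change of group on this oxygen on an aromatic ring can bring the read-out within the measured range. With 1-((dimethylamino)methyl)ethyl in place of (ethoxymethyl)carbonyl the result is an at least 2.0-fold lower number from compound 2 to compound 3 (0.30 log units; that floor lies within the scatter), and with the same group in place of methyl it is an at least 2.0-fold lower number from compound 1 to compound 3 (0.30 log units; that floor lies within the scatter). The step between the other two compounds cannot be read, and these two new steps give only floors, so their true sizes stay unknown, as both rest on a shared limit: the limit of > 30000 nM in this assay, at which 2 of the 3 values shown sit.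

The compounds shown leave open whether the nitrogen of the entering group matters or whether its carbon chain alone would give a similar reading, a question that an isopropyl group on this oxygen would address. They also leave open how a longer chain ending in a dimethylamino group, or a morpholine carried on a chain at the same oxygen, would read in this assay.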